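Replacing the 4-nitrophenyl group of compound 3

The source may hold more compounds than are shown below. What is called first, only, known or untested is meant among the compounds shown, and "the series" means these compounds.

In a functional assay on MCF7 cells (Homo sapiens) for antiproliferative activity, read by MTT assay, with a stated time of 48 h (on this read-out lower numbers stand for stronger inhibition and higher numbers for weaker inhibition), compound 3 `COc1cc(/C=C/C(C)=O)ccc1OCc1cn(-c2ccc([N+](=O)[O-])cc2)nn1` gives > 100000 nM, which is a limit of the assay and not a number. Compound 2 `COc1cc(/C=C/C(C)=O)ccc1OCc1cn(-c2ccc(NC(=O)c3ccccc3)cc2)nn1` gives 86700 nM and compound 1 `COc1cccc(-n2cc(COc3ccc(/C=C/C(C)=O)cc3OC)nn2)c1` gives 1800 nM. Compound 4 `COc1cc(/C=C/C(C)=O)ccc1OCc1cn(-c2cc(F)cc(Br)c2)nn1` is still unmeasured and carries 3-bromo-5-fluorophenyl in place of 4-nitrophenyl on an aromatic nitrogen.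

Within the data shown here, two measured steps bear on this change. Putting 4-nitrophenyl in place of 3-methoxyphenyl at the same nitrogen gave an at least 55-fold higher number from compound 1 to compound 3 (1.74 log units; beyond the scatter), a large step. Nitro in place of benzamido gave an at least 1.1-fold higher number from compound 2 to compound 3 (0.06 log units; that floor lies within the scatter), so compound 2 is not separated from the limit. Leaving 4-nitrophenyl therefore does not ensure a gain, but compound 1 at 1800 nM shows that a large one is possible at this nitrogen. Among the measured compounds shown here, a sizeable step toward stronger inhibition is expected, probably smaller than the one separating compound 1 from compound 3. The expected step is an at least 11-fold lower number from compound 3 to compound 4 (1.04 log units; beyond the scatter). The estimated value for compound 4 is 9000 nM, with an expected range from 1500 nM to 60000 nM.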

Compound 4, half-maximal inhibitory concentration: 65500 nM
The estimate for compound 4 lay 7.3-fold (0.86 log units) below the measured number; the whole stated range lies below it.
By their numbers in this assay, from the lowest: compound 1; then compounds 4 and 2 (each within the scatter of the next). At a limit, above all of these: compound 3.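

Leaving 4-nitrophenyl for 3-bromo-5-fluorophenyl gives, in this assay, an at least 1.5-fold lower number from compound 3 to compound 4 (0.18 log units; that floor lies within the scatter), so this change is not shown to bring a gain at this nitrogen. Compound 3 is held at a limit and not a number, which leaves that step only a floor: the limit of > 100000 nM in this assay, at which 1 of the 4 values shown sits. The change from 3-methoxyphenyl to 3-bromo-5-fluorophenyl gives a 36-fold higher number from compound 1 to compound 4 (1.56 log units; beyond the scatter), so moving away from 4-nitrophenyl is not enough in itself, and among the aryl groups shown only the 3-methoxyphenyl of compound 1 goes with a low number.

Going by these compounds, it remains open whether that low number depends on the methoxy group itself or on where it sits on the phenyl ring. Unsubstituted phenyl, 4-methoxyphenyl and 3-hydroxyphenyl at the same nitrogen would separate these readings.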